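Swapping methyl for bromo on a phenyl ring

This account rests on a few compounds, and the source may have more. Where it says the series, first, only, none or still open, it means among the compounds named here.

In a functional assay on HCT-116 cells (Homo sapiens) for antiproliferative activity, read by MTT assay, with a stated time of 72 h (on this read-out lower numbers stand for stronger inhibition and higher numbers for weaker inhibition), compound 3 `Cc1ccc(OCCCON2C(N)=NC(N)=NC23CCOCC3)cc1` gives 2390 nM and stands second highest of three measured numbers. Compound 1 `NC1=NC2(CCOCC2)N(OCCCOc2cc(Cl)c(Cl)cc2Cl)C(N)=N1` gives 2750 nM and so sits level with it, with no order between the two. The step between them reads a 1.2-fold lower number from compound 1 to compound 3 (0.06 log units; within the scatter) and shows two different phenyl groups giving much the same number. Compound 2 `NC1=NC2(CCOCC2)N(OCCCOc2cccc(Br)c2)C(N)=N1` gives 40 nM and is the most potent of the three.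

Compound 4 `NC1=NC2(CCOCC2)N(OCCCOc2ccc(Br)cc2)C(N)=N1` changes compound 3 at a single spot: bromo in place of methyl on an aromatic carbon and in words this is bromo in place of methyl on an aromatic carbon, turning 4-methylphenyl into 4-bromophenyl.

Among the compounds with values here, no measured step makes exactly this swap. The closest is a 60-fold higher number from compound 2 to compound 3 (1.78 log units; beyond the scatter) and it is large, but it differs from the new change. Compound 2 carries a 3-bromophenyl, so the bromo sits elsewhere on its ring. The step of a 69-fold lower number from compound 1 to compound 2 (1.84 log units; beyond the scatter) is equally large and also sets compound 2 apart. Only part of such a drop can be expected to carry over to a 4-bromophenyl. The expected move is therefore a moderate one toward a lower number, estimated as a 6.8-fold lower number from compound 3 to compound 4 (0.83 log units; beyond the scatter) and held loosely. In this assay the estimated value for compound 4 is 350 nM (expected range 40 nM to 2800 nM).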

Compound 4, half-maximal inhibitory concentration: 320 nM
Compound 4: the middle estimate sits 1.1-fold (0.04 log units) above what was measured; the measured number falls inside the stated range.
By their numbers in this assay, from the lowest: compound 2; then compound 4; then compounds 3 and 1 (each within the scatter of the next).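

In this assay, within the data shown here, a 7.5-fold lower number from compound 3 to compound 4 (0.87 log units; beyond the scatter) gives the first direct reading of this change, bromo in place of methyl on an aromatic carbon para to a large group, with the rest of the molecule untouched. Bromo alone does not account for the potency of compound 2, since an 8.0-fold higher number from compound 2 to compound 4 (0.90 log units; beyond the scatter) shows that 4-bromophenyl and 3-bromophenyl give clearly different numbers, so where the bromo sits on the ring matters here. The new compound also stands apart from the trichlorinated one, with an 8.6-fold lower number from compound 1 to compound 4 (0.93 log units; beyond the scatter) for 4-bromophenyl in place of 2,4,5-trichlorophenyl, and no measurement shown here explains why any of these groups differ.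

As far as these compounds go, whether a chloro, a methoxy or an amine at the same place would give a number nearer that of compound 2 or that of compound 3 remains open. From the compounds shown here alone, it is also open whether a 3-methylphenyl would show the same gap from 4-methylphenyl that separates the two bromophenyl compounds, which would tell whether this ring preference extends beyond bromo.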